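A few compounds are considered here, and "the series" means these few. Any claim that something is new, unique, unknown or untested is made for them only; others in the source may bear on it.

In a functional assay on cells (Panel NCI-60 (60 carcinoma cell lines), Homo sapiens) for inhibition, read by colorimetric assay, with a stated time of 3 days (a higher number here means a weaker inhibitor of growth, a lower number a stronger inhibitor of growth), compound 2 `COc1ccc(-c2cnc(NC(=O)CCCCCCNC(=O)C(O)(O)C(F)(F)F)s2)cc1` gives 8510 nM. Among the measured compounds shown here, this is the only number available, so it cannot yet be ranked against anything. For compound 1 `COc1ccc(OC)c(NC(=O)CCCCCCNC(=O)C(O)(O)C(F)(F)F)c1`, the entry reads "not determined" (no result reported), which offers no comparison.

Compound 3 `O=C(CCCCCCNC(=O)C(O)(O)C(F)(F)F)Nc1ncc(-c2ccc(Br)cc2)s1` has not yet been measured. Compared with compound 2, it carries one change, bromo in place of methoxy on an aromatic carbon, so that 4-methoxyphenyl becomes 4-bromophenyl. For the measured compounds named here, no measured pair shows what a swap of this kind does, so no step beyond the usual scatter is expected in this assay, and no direction can be favoured. This expectation rests on compound 2 alone, at 8510 nM, and so remains loose. The expected change is a 1.1-fold lower number from compound 2 to compound 3 (0.03 log units; within the scatter). For compound 3, the estimated value is 8000 nM, with an expected range from 3000 nM to 22000 nM.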

Compound 3, concentration for total growth inhibition: 11400 nM
Compound 3: the middle estimate sits 1.4-fold (0.15 log units) below what was measured; the range from low to high includes it.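

In this assay, placing bromo instead of methoxy on the aromatic carbon para to a large group gives a 1.3-fold higher number from compound 2 to compound 3 (0.13 log units; within the scatter) and so leaves the two compounds indistinguishable. This first measured pair shows that growth inhibition at this position holds with either group, even though the swap removes a hydrogen-bond acceptor. No measurement shown here offers an explanation for this result.

Among the compounds shown here, one pair covers only two groups at one position, so it remains open whether an amine or a carboxylic acid at the same place would also read alike. A longer chain between the amide and the hydrated trifluoroacetyl end is also untested among these compounds, and compound 1 has no number to compare.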